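Varying the Amide Aryl Group on a Shared Core

The source may report more compounds than this note shows. Statements on the series, on what has been measured and on what is new or still open speak of the compounds shown alone.

Compound 1 `CN1[C@@H]2c3[nH]c4ccccc4c3C[C@H]1[C@H](C#N)N1[C@@H](CNC(=O)c3ccc(F)cc3)c3[nH]c4ccccc4c3C[C@@H]21` gives 980 nM in a functional assay on MCF7 cells (Homo sapiens) for cytotoxicity, read by MTT assay, with a stated time of 72 h; on this read-out higher numbers stand for weaker inhibition and lower numbers for stronger inhibition.
Compound 2 `CCc1ccc(C(=O)NC[C@H]2c3[nH]c4ccccc4c3C[C@H]3[C@H]4c5[nH]c6ccccc6c5C[C@@H]([C@H](C#N)N23)N4C)cc1` gives 170 nM in this assay.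
Compound 3 `CN1[C@@H]2c3[nH]c4ccccc4c3C[C@H]1[C@H](C#N)N1[C@@H](CNC(=O)c3ccc4ccccc4n3)c3[nH]c4ccccc4c3C[C@@H]21` gives 150 nM in this assay.

Among these three, compound 2 has the second highest number in this assay; compound 3 lies nearest, as a 1.1-fold lower number from compound 2 to compound 3 (0.05 log units; within the scatter) is within the scatter, while compound 1 is furthest, with a 5.8-fold lower number from compound 1 to compound 2 (0.76 log units; beyond the scatter) beyond the scatter. Compound 4 `CN1[C@@H]2c3[nH]c4ccccc4c3C[C@H]1[C@H](C#N)N1[C@@H](CNC(=O)/C=C/c3cccc(C(F)(F)F)c3)c3[nH]c4ccccc4c3C[C@@H]21` differs from compound 2 by 2-(3-(trifluoromethyl)phenyl)ethenyl in place of 4-ethylphenyl on a carbonyl carbon. For the measured compounds named here, the steps that bear on this change all alter the group on the carbonyl carbon: a 5.8-fold lower number from compound 1 to compound 2 (0.76 log units; beyond the scatter) and a 6.5-fold lower number from compound 1 to compound 3 (0.82 log units; beyond the scatter) were modest, whereas a 1.1-fold lower number from compound 2 to compound 3 (0.05 log units; within the scatter) was within the scatter. Two different aryl groups thus gave numbers within the scatter of each other, so no step beyond the scatter is expected here; the expected step is a 1.2-fold higher number from compound 2 to compound 4 (0.07 log units; within the scatter). Compound 4 is therefore expected to give 200 nM, with a range from 70 nM to 600 nM.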

Compound 4, half-maximal inhibitory concentration: 110 nM
Estimate against measurement, compound 4: 1.8-fold (0.26 log units) above; measured number inside the range.
By their numbers in this assay, from the lowest: compounds 4, 3 and 2 (each within the scatter of the next); then compound 1.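

In this assay the 2-(3-(trifluoromethyl)phenyl)ethenyl group on the carbonyl carbon, with its double bond outside aromatic rings, cannot be told apart from 4-ethylphenyl or quinolin-2-yl: a 1.5-fold lower number from compound 2 to compound 4 (0.19 log units; within the scatter) and a 1.4-fold lower number from compound 3 to compound 4 (0.13 log units; within the scatter) both lie within the scatter. Only the comparison with 4-fluorophenyl separates, with an 8.9-fold lower number from compound 1 to compound 4 (0.95 log units; beyond the scatter) beyond the scatter, so among these four groups 4-fluorophenyl alone stands apart. Nothing available explains this result. On these data alone, whether an amine, a carboxylic acid or a longer chain on the carbonyl carbon would fit the same picture stays open. The compounds shown also leave open what the double bond and the trifluoromethyl group each contribute alone.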